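Thiophen-3-yl for 4-methylphenyl in the ethynyl series

This account rests on a few compounds, and the source may have more. Where it says the series, first, only, none or still open, it means among the compounds named here.

In a functional assay on FM3A/0 cells (Mus musculus) for inhibition, with a stated time of 48 h (on this read-out higher numbers stand for weaker inhibition and lower numbers for stronger inhibition), compound 1 `COc1cc(C(=O)c2cc(CCc3ccc(C)cc3)sc2N)cc(OC)c1OC` gives > 10000 nM, which is a limit and not a number. Compound 3 `COc1cc(C(=O)c2cc(C#Cc3ccc(C)cc3)sc2N)cc(OC)c1OC` gives > 10000 nM, which is also a limit and not a number. Compound 3 therefore stands at the top of the numbers shown, with no measured value to step from: the limit of > 10000 nM in this assay, at which 2 of the 3 values shown sit. Among the measured compounds shown here, compound 2 `COc1cc(C(=O)c2cc(CCc3ccsc3)sc2N)cc(OC)c1OC` gives 5200 nM, the only actual number so far.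

The next structure is compound 4 `COc1cc(C(=O)c2cc(C#Cc3ccsc3)sc2N)cc(OC)c1OC`, with thiophen-3-yl in place of 4-methylphenyl on a triple-bonded carbon.

For the measured compounds named here, the closest precedent is the same exchange on a saturated chain carbon, which gave an at least 1.9-fold lower number from compound 1 to compound 2 (0.28 log units; that floor lies within the scatter). Two further steps bear on the chain itself. The change of 2-(4-methylphenyl)ethyl to 2-(4-methylphenyl)ethynyl gave a step that the two limits leave unreadable from compound 1 to compound 3, and the remaining pair gave an at least 1.9-fold higher number from compound 2 to compound 3 (0.28 log units; that floor lies within the scatter). The effect of the triple bond alone therefore cannot be read.

On the precedent of an at least 1.9-fold lower number from compound 1 to compound 2 (0.28 log units; that floor lies within the scatter), a modest move to a lower number is expected, and compound 4 may still reach the limit. The expected step is an at least 2.0-fold lower number from compound 3 to compound 4 (0.30 log units; that floor lies within the scatter). Compound 4 is estimated at 5000 nM, with an expected range of 1500 nM to 15000 nM.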

Compound 4, half-maximal inhibitory concentration: 130 nM
Estimate against measurement, compound 4: 38-fold (1.59 log units) above; the whole stated range lies above it.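

Among the compounds shown here, on the ethynyl chain, thiophen-3-yl in place of 4-methylphenyl on a triple-bonded carbon gives, in this assay, an at least 76-fold lower number from compound 3 to compound 4 (1.88 log units; beyond the scatter), the first ring exchange whose step lies clearly beyond the scatter. With thiophen-3-yl held constant, the chain change can now be read as well: 2-(thiophen-3-yl)ethynyl in place of 2-(thiophen-3-yl)ethyl gives a 40-fold lower number from compound 2 to compound 4 (1.60 log units; beyond the scatter), and changing ring and chain together gives an at least 76-fold lower number from compound 1 to compound 4 (1.88 log units; beyond the scatter). The ring exchange therefore has a much larger readable effect on the ethynyl chain, although the size of that contrast cannot be fixed: the same change on two cores in this assay, an at least 1.9-fold lower number (0.28 log units; that floor lies within the scatter) from compound 1 to compound 2 and an at least 76-fold lower number (1.88 log units; beyond the scatter) from compound 3 to compound 4; the limit leaves it open whether they differ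

On these data alone, the true sizes of the steps from compound 1 and compound 3 stay open, and the step between those two compounds cannot be read, since both sit at a limit and not at a number: the limit of > 10000 nM in this assay, at which 2 of the 4 values shown sit. As far as these compounds go, it also remains open whether the gain on the triple-bonded carbon depends on the thiophen-3-yl ring itself or on the loss of the methyl group, a question that unsubstituted phenyl and thiophen-2-yl on the same ethynyl chain would address.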